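Swapping an Aromatic Ring for a Dione Ring

The compounds below may be only part of what the source reports. "The series", "measured", "known", "first", "only" and "open" are said of these compounds alone.

Compound 2 `Cc1cc(C)n(C(=O)c2nn(-c3ccc(Cl)cc3)cc2O)n1` — 7050 nM
Compound 1 `CC1=NN(C(=O)c2nn(-c3ccc(Cl)cc3)cc2O)C(=O)C1` — "not determined" (no result reported)

Two compounds share the same core and were put into a functional assay on PC-3 cells (Homo sapiens) for inhibition, read by sulforhodamine B assay, with a stated time of 48 h; a lower number here means a stronger inhibitor of growth, a higher number a weaker inhibitor of growth. For compound 1 the entry reads "not determined" (no result reported), so no number was reported. Among the compounds with values here, compound 2 gives 7050 nM in this assay, and as the only number in hand it stands alone, with nothing to rank it against. Compound 3 `O=C1CC(=O)N(C(=O)c2nn(-c3ccc(Cl)cc3)cc2O)N1` is next to be measured. It differs from compound 2 in one place: a group of 7 heavy atoms (3 carbon, 2 nitrogen, 2 oxygen; one five-membered non-aromatic ring with 2 hetero atoms) in place of a group of 7 heavy atoms (5 carbon, 2 nitrogen; one five-membered aromatic ring with 2 hetero atoms), on a carbonyl carbon, in words a group of 7 heavy atoms (3 carbon, 2 nitrogen, 2 oxygen; one five-membered non-aromatic ring with 2 hetero atoms) in place of a group of 7 heavy atoms (5 carbon, 2 nitrogen; one five-membered aromatic ring with 2 hetero atoms), on a carbonyl carbon. Within the data shown here, no step between measured compounds exists to guide the size of this change. The expectation is a modest step toward weaker growth inhibition, just beyond the usual scatter, a 2.1-fold higher number from compound 2 to compound 3 (0.33 log units; beyond the scatter). Compound 3 is estimated at 15000 nM, with a range from 5000 nM to 45000 nM.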

Compound 3, concentration for 50% growth inhibition: 360 nM
Compound 3: the middle estimate sits 42-fold (1.62 log units) above what was measured; the whole stated range lies above it.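

On a carbonyl carbon of the shared core, this one change gives a large shift in this assay, a 20-fold lower number from compound 2 to compound 3 (1.29 log units; beyond the scatter). The position is therefore sensitive to what it carries, even though the group that leaves and the group that enters have the same count of heavy atoms and both are five-membered rings with 2 hetero atoms. The entering ring is non-aromatic, has 2 oxygen atoms and 2 double bonds outside aromatic rings, and adds 1 hydrogen-bond donor, but nothing in hand separates these differences or ties the shift to any one of them.

From the compounds shown here alone, it remains open whether a ring is needed here at all, as a simple amine or a short open chain on this carbonyl carbon would show. Also open, going by these compounds, is whether the two oxygen atoms must both be present.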